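A few compounds are considered here, and "the series" means these few. Any claim that something is new, unique, unknown or untested is made for them only; others in the source may bear on it.

Measured so far: compound 1 `FC(F)(F)c1nc2c(Br)cccc2c(Cl)c1Br`, compound 2 `FC(F)(F)c1nc2c(-c3ccccc3)cccc2c(-c2ccccc2)c1-c1ccccc1`, compound 3 `COc1ccc(-c2c(C(F)(F)F)nc3c(-c4ccc(OC)cc4)cccc3c2-c2ccc(OC)cc2)cc1`.

In an assay for inhibition of ectonucleoside triphosphate diphosphohydrolase 1 (Homo sapiens), read by malachite green, with a stated time of 10 min (on this read-out lower numbers stand for stronger inhibition and higher numbers for weaker inhibition), compound 1 reaches only the limit of the assay, > 300000 nM. Compound 2 likewise reaches only the limit, > 300000 nM. Compound 3 also reaches only the limit, > 300000 nM. Among the measured compounds shown here, compound 1 therefore stands at the limit, as do both other measured compounds, and no step between measured compounds can be sized from these data. The change from compound 1 to compound 4 `COc1ccc(-c2cccc3c(Cl)c(Br)c(C(F)(F)F)nc23)cc1` is 4-methoxyphenyl in place of bromo on an aromatic carbon. Compound 4 is expected near 300000 nM, with a range from 100000 nM to 1000000 nM, because of the limit of > 300000 nM in this assay, at which 3 of the 3 values shown sit. The step of a number no higher from compound 1 to compound 4 (the limit leaves the size open) is expected to be none beyond the scatter, so a further limit is the most likely outcome.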

Compound 4, half-maximal inhibitory concentration: > 300000 nM
Compound 4: a limit, no number; the forecaster's own chance of this, stated with the estimate: 80%; the middle value sits exactly at the limit.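

Among the compounds shown here, compound 1 and compound 4 both give only a limit in this assay, so no step between them can be read. The compounds shown leave open whether any change on the shared core would yield a measurable value.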